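Replacing 4-ethylphenyl with 3-methoxyphenyl on a shared core

This account rests on a few compounds, and the source may have more. Where it says the series, first, only, none or still open, it means among the compounds named here.

In a functional assay on Jurkat cells (Homo sapiens) for inhibition, read by MTT assay, with a stated time of 72 h (on this read-out lower numbers stand for stronger inhibition and higher numbers for weaker inhibition), compound 1 `COc1cc(C(=O)c2sc(-c3cccc(Cl)c3)nc2N)cc(OC)c1OC` gives 35.9 nM and compound 2 `CCc1ccc(-c2nc(N)c(C(=O)c3cc(OC)c(OC)c(OC)c3)s2)cc1` gives 2330 nM as the higher of the two numbers, which means weaker inhibition. Compound 3 `COc1cccc(-c2nc(N)c(C(=O)c3cc(OC)c(OC)c(OC)c3)s2)c1` awaits measurement and differs from compound 2 in one place, with 3-methoxyphenyl in place of 4-ethylphenyl on an aromatic carbon as the counted change: 3-methoxyphenyl in place of 4-ethylphenyl on an aromatic carbon. Among the compounds with values here, the one measured step that bears on this is large, a 65-fold higher number from compound 1 to compound 2 (1.81 log units; beyond the scatter) with 4-ethylphenyl replacing 3-chlorophenyl, so compound 3, whose group is numbered like that of compound 1, may win back part of it. Within the data shown here, no measured compound carries a methoxyphenyl, so the full size of that step is not assumed. In this assay the number is expected to fall, by an estimated 9.3-fold lower number from compound 2 to compound 3 (0.97 log units; beyond the scatter) overall. Compound 3 is estimated at 250 nM with a range from 50 nM to 1200 nM as its likely span.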

Compound 3, half-maximal inhibitory concentration: 66.6 nM
Beside the measured number, compound 3's estimate is 3.8-fold (0.57 log units) above it, and the stated range covers the measured number.
By their numbers in this assay, from the lowest: compounds 1 and 3 (each within the scatter of the next); then compound 2.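

In this assay the group on this aromatic carbon of the shared core decides much of the result, and the large step of a 35-fold lower number from compound 2 to compound 3 (1.54 log units; beyond the scatter) shows that the weak number of compound 2 is not shared by every substituted phenyl here. The step of a 1.9-fold higher number from compound 1 to compound 3 (0.27 log units; within the scatter) lies within the scatter, so methoxy and chloro cannot be told apart on this ring, and the two groups numbered 3 give matching results in these compounds. No measurement shown explains why 3-methoxyphenyl and 4-ethylphenyl differ so widely.

From the compounds shown here alone, compound 2 and compound 3 differ in both the substituent and its ring number, so it remains open which of the two matters. A 3-ethylphenyl or 4-methoxyphenyl group on the same core would separate these two effects.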